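Replacing methanesulfonamido on the saturated ring of compound 3

A few compounds are considered here, and "the series" means these few. Any claim that something is new, unique, unknown or untested is made for them only; others in the source may bear on it.

Measured in an ADME assay on Vero cells (Chlorocebus sabaeus) for cytotoxicity, read by MTT assay, with a stated time of 48 h; a higher number here means a weaker inhibitor, a lower number a stronger inhibitor:
compound 1 `O=c1cc(N2CCN(CC3CCC(OS(=O)(=O)c4cccnc4)CC3)CC2)sc2c([N+](=O)[O-])cc(C(F)(F)F)cc12`: > 64 ug/mL (a limit)
compound 2 `CC(C)S(=O)(=O)OC1CCC(CN2CCN(c3cc(=O)c4cc(C(F)(F)F)cc([N+](=O)[O-])c4s3)CC2)CC1`: > 64 ug/mL (a limit)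
compound 3 `CS(=O)(=O)NC1CCC(CN2CCN(c3cc(=O)c4cc(C(F)(F)F)cc([N+](=O)[O-])c4s3)CC2)CC1`: 48.5 ug/mL

Of these three, compound 3 alone has a true number, 48.5 ug/mL. Compound 1 and compound 2 both stand at the limit of > 64 ug/mL in this assay, at which 2 of the 3 values shown sit.

Compound 4 `O=C(OC1CCC(CN2CCN(c3cc(=O)c4cc(C(F)(F)F)cc([N+](=O)[O-])c4s3)CC2)CC1)c1ccncc1` carries ((pyridin-4-yl)carbonyl)oxy in place of methanesulfonamido on a saturated ring carbon.

The nearest evidence runs from oxygen-linked groups to methanesulfonamido: an at least 1.3-fold lower number from compound 1 to compound 3 (0.12 log units; that floor lies within the scatter) and an at least 1.3-fold lower number from compound 2 to compound 3 (0.12 log units; that floor lies within the scatter). Read in reverse, these steps suggest only a small rise in this assay, with none expected beyond the scatter. The expected step is a 1.2-fold higher number from compound 3 to compound 4 (0.09 log units; within the scatter). For compound 4 the estimated value is 60 ug/mL, with an expected range from 32 ug/mL to 110 ug/mL.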

Compound 4, half-maximal inhibitory concentration: > 64 ug/mL
Compound 4: no number, only a limit; the forecaster's own chance of this, stated with the estimate: 55%; at least 1.0-fold (0.02 log units) between middle value and limit.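

With a carbonyl in place of a sulfonyl on the oxygen, compound 4 also gives only a limit, not a number, so its step from the methanesulfonamido compound is just a floor: an at least 1.3-fold higher number from compound 3 to compound 4 (0.12 log units; that floor lies within the scatter). Both ends are limits on the steps linking compound 4 to compound 1 and compound 2, and those steps cannot be read. An oxygen-linked group on this saturated ring carbon therefore need not carry a sulfonyl to sit at the limit: the limit of > 64 ug/mL in this assay, at which 3 of the 4 values shown sit.

From the compounds shown here alone, what an amine or an acetamido group on this same carbon would give stays open.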